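This account rests on a few compounds, and the source may have more. Where it says the series, first, only, none or still open, it means among the compounds named here.

Of the compounds shown here, two of a shared core have been tested so far. Compound 1 `NS(=O)(=O)c1ccc(/N=C2\NC(=O)/C(=C3/C(=O)Nc4ccc([N+](=O)[O-])cc43)S2)cc1` gives 13800 nM in a functional assay on Caco-2 cells (Homo sapiens) for antiproliferative activity, read by MTT assay (on this read-out lower numbers stand for stronger inhibition and higher numbers for weaker inhibition), and compound 2 `NS(=O)(=O)c1cccc(/N=C2\NC(=O)/C(=C3/C(=O)Nc4ccc(Cl)cc43)S2)c1` gives 5870 nM in this assay. Compound 2 thus stands at the lowest of the two numbers, and compound 1 sits at a number beyond the scatter above it. The two differ in more than one place, so no single change can be read from their values.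

Compound 3 `NS(=O)(=O)c1cccc(/N=C2\NC(=O)/C(=C3/C(=O)Nc4ccc([N+](=O)[O-])cc43)S2)c1` is the next member and has not yet been measured in this assay. It differs from compound 2 in one place only: nitro in place of chloro on an aromatic carbon. Going by the values given here, no measured pair isolates this exchange, so the step cannot be read from the data; the only hint is that compound 1, which also carries the nitro group, gives 13800 nM, a weaker number than compound 2. On that basis a modest step toward a higher number, possibly within the scatter, is expected from compound 2 to compound 3 a 1.5-fold higher number from compound 2 to compound 3 (0.19 log units; within the scatter). Compound 3 is therefore estimated to give 9000 nM in this assay, with a plausible range from 4000 nM to 20000 nM.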

Compound 3, half-maximal inhibitory concentration: 20600 nM
For compound 3 the middle estimate is 2.3-fold (0.36 log units) below the measured one; the measured number lies above the stated range.
By their numbers in this assay, from the lowest: compound 2; then compounds 1 and 3 (each within the scatter of the next).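

Going by these compounds alone, with the 3-sulfamoylphenyl group held fixed, nitro in place of chloro on the aromatic carbon gives a 3.5-fold higher number from compound 2 to compound 3 (0.55 log units; beyond the scatter) in this assay and so isolates this exchange for the first time, with chloro as the group giving the lower number of the two at this position. With nitro held fixed, 3-sulfamoylphenyl in place of 4-sulfamoylphenyl on the double-bonded nitrogen gives a 1.5-fold higher number from compound 1 to compound 3 (0.17 log units; within the scatter), so this read-out does not separate these two groups on the nitrogen. Nothing available here explains the step from chloro to nitro.

The compounds shown leave open whether the chloro and nitro exchange gives a step of similar size when 4-sulfamoylphenyl sits on the double-bonded nitrogen, since chloro appears only with the 3-sulfamoylphenyl group. They also leave open how other groups on this aromatic carbon, such as fluoro, bromo, methoxy or an amine, would compare with chloro, and whether any of them would reach a lower number than compound 2 at 5870 nM in this assay.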